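The source may hold more compounds than are shown below. What is called first, only, known or untested is meant among the compounds shown, and "the series" means these compounds.

Measured compounds:
Compound 1, `C/C=C(\COC(=O)c1ccccc1)C(=O)c1ccc(OC)cc1`, a functional assay on A549 cells (Homo sapiens) for inhibition, read by XTT assay, with a stated time of 48 h; on this read-out lower numbers stand for stronger inhibition and higher numbers for weaker inhibition: > 100000 nM
Compound 2, `C=C(C(=O)c1ccc(OC)cc1)C(OC(C)=O)c1ccc(Cl)cc1Cl`, this assay: 17600 nM

Of the compounds shown here, two have been measured, and only one of them gives a number. For compound 1 the result is a limit of the assay, > 100000 nM, and not a measured value (the limit of > 100000 nM in this assay, at which 1 of the 2 values shown sits). Going by the values given here, compound 2 is therefore the only compound with an actual number in this assay, 17600 nM, and it stands alone. The two results can be compared no further than to say that compound 2 gives a number where compound 1 does not.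

The unmeasured compound 3, `C=C(C(=O)c1ccc(OC)cc1)C(OC(C)=O)C1CCCCC1`, differs from compound 2 in a single place: cyclohexyl in place of 2,4-dichlorophenyl on a saturated chain carbon bound to a double-bonded chain carbon and an oxygen next to a carbonyl group. Among the compounds with values here, no step between measured compounds covers this kind of change, so there is no measured basis for its size or direction. It is expected that the step of a 1.7-fold higher number from compound 2 to compound 3 (0.23 log units; within the scatter) goes toward weaker inhibition, though a step within the scatter would not be surprising. Compound 3 is estimated at 30000 nM, within 8000 nM to 100000 nM.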

Compound 3, half-maximal inhibitory concentration: > 100000 nM
Compound 3: only a limit was reported; the forecaster's own chance of this, stated with the estimate: 30%; middle value at least 3.3-fold (0.52 log units) away from the limit.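

Going by these compounds alone, this is the first step in this assay that can be read between two compounds differing in one place, and it shows that the group on this saturated chain carbon matters: cyclohexyl in place of 2,4-dichlorophenyl gives an at least 5.6-fold higher number from compound 2 to compound 3 (0.75 log units; beyond the scatter), toward weaker inhibition. As far as these compounds go, compound 3 gives > 100000 nM, which is a limit of the assay and not a number, so the step has a lower bound only and its full size stays unknown. Of the compounds shown, only compound 2 now carries a number, and the other two stand at one limit: the limit of > 100000 nM in this assay, at which 2 of the 3 values shown sit.

The compounds shown leave open whether the step follows the loss of the aromatic ring or the loss of the two chlorine atoms, a question that an unsubstituted phenyl or a 4-chlorophenyl at this place would help to separate. They also leave open whether the number of compound 2 would survive if its acetyl ester gave way to a hydroxyl or an amine.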